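The source may report more compounds than this note shows. Statements on the series, on what has been measured and on what is new or still open speak of the compounds shown alone.

Compound 1 `COc1cc(OC)c2sc(-c3ccc(N/C=C\C(=O)c4ccc(OC)c(O)c4)c(C)c3)nc2c1`, compound 2 `COc1ccc(C(=O)/C=C\Nc2ccc(-c3nc4cc(OC)c(OC)c(OC)c4s3)cc2C)cc1O` and compound 3 `COc1cc(OC)c2sc(-c3ccc(N/C=C\C(=O)c4cc(OC)c(OC)c(OC)c4Br)c(C)c3)nc2c1` have each been tested in a functional assay on A549 cells (Homo sapiens) for antiproliferative activity, read by sulforhodamine B assay, with a stated time of 48 h; a lower number here means a stronger inhibitor, a higher number a weaker inhibitor. There compound 1 gives 14300 nM, compound 2 gives 15400 nM and compound 3 gives 14000 nM; all three numbers lie within the scatter of one another. Compound 2 differs from compound 1 in a single place, (methoxy in place of hydrogen on an aromatic carbon), and this change made a step of a 1.1-fold higher number from compound 1 to compound 2 (0.03 log units; within the scatter). How the core of compound 1 differs from the core of compound 3 is not broken down here. Compound 4 `COc1cc(C(=O)/C=C\Nc2ccc(-c3nc4cc(OC)c(OC)c(OC)c4s3)cc2C)c(Br)c(OC)c1OC` has not yet been measured in this assay. It differs from compound 3 by methoxy in place of hydrogen on an aromatic carbon, the same change seen between compound 1 and compound 2; it occurs twice among these four compounds. Because the earlier step was a 1.1-fold higher number from compound 1 to compound 2 (0.03 log units; within the scatter), the expected step here is about the same, a 1.1-fold higher number from compound 3 to compound 4 (0.03 log units; within the scatter). Starting from compound 3 with its 14000 nM, compound 4 is expected to give about 15000 nM, most likely between 7500 nM and 30000 nM.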

Compound 4, half-maximal inhibitory concentration: 10300 nM
Estimate against measurement, compound 4: 1.5-fold (0.16 log units) above, within the range that was stated.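

In this assay, putting a methoxy in place of hydrogen on an aromatic carbon of the core of compound 3 gave a 1.4-fold lower number from compound 3 to compound 4 (0.13 log units; within the scatter), a step too small to tell apart from repeat-measurement noise. Set beside the same change on the core of compound 1, the two steps agree as far as these measurements can tell: the same change on two cores in this assay, a 1.1-fold higher number (0.03 log units; within the scatter) from compound 1 to compound 2 and a 1.4-fold lower number (0.13 log units; within the scatter) from compound 3 to compound 4, 1.5-fold (0.17 log units) apart, within the scatter of two such steps. So across these two pairs the change carries from one core to the other without a step beyond the scatter, but two pairs cannot show that this would hold on other cores, nor can they explain the result.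

Still open, on these data alone, is whether a different group on that same aromatic carbon, such as an amine, a carboxylic acid or a longer chain, would move the number beyond the scatter. As far as these compounds go, it is also open whether the methoxy change would stay this small on a core that gives a much lower number in this assay.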